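Exchanging the (furan-3-yl)carbonyl group of compound 1

The source may hold more compounds than are shown below. What is called first, only, known or untested is meant among the compounds shown, and "the series" means these compounds.

Measured in a functional assay on A549 cells (Homo sapiens) for antiproliferative activity, read by XTT assay, with a stated time of 72 h; on this read-out lower numbers stand for stronger inhibition and higher numbers for weaker inhibition:
Compound 1 `C=C(C)CCC[C@]1(C)C2=CCC[C@](C)(CC(=O)c3ccoc3)[C@H]2CC[C@H]1C`: > 100000 nM, a limit of the assay
Compound 2 `CC(C)=CCC[C@]1(C)C2=CCC[C@](C)(CC(=O)c3ccoc3)[C@H]2CC[C@H]1C`: 91000 nM

Compound 1 gives no number, only a limit: the limit of > 100000 nM in this assay, at which 1 of the 2 values shown sits. For the measured compounds named here, the single measured step, an at least 1.0-fold lower number from compound 1 to compound 2 (0.04 log units; that floor lies within the scatter), lies within the scatter. It also falls at a different place from the change considered here, so it sets no size for that change.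

Compound 3 `C=C(C)CCC[C@]1(C)C2=CCC[C@](C)(C[C@H](O)C3=CC(=O)OC3O)[C@H]2CC[C@H]1C` keeps the core of compound 1 but exchanges one group: a group of 9 heavy atoms (5 carbon, 4 oxygen; one five-membered non-aromatic ring with 1 hetero atom) in place of a group of 7 heavy atoms (5 carbon, 2 oxygen; one five-membered aromatic ring with 1 hetero atom), on a saturated chain carbon bound to a saturated ring carbon. Going by the values given here, no measured step covers this exchange, so the expectation is uncertain. A move towards stronger inhibition in this assay is expected, with an estimated at least 5.0-fold lower number from compound 1 to compound 3 (0.69 log units; beyond the scatter). For compound 3 the expected value is 20000 nM, with an estimated range of 4000 nM to 100000 nM.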

Compound 3, half-maximal inhibitory concentration: 3200 nM
For compound 3 the middle estimate is 6.3-fold (0.80 log units) above the measured one; measured number below the stated range.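

In this assay, the place named in the exchange, a saturated chain carbon bound to a saturated ring carbon, proves sensitive to the group it carries, which the earlier pair could not show: the exchange gives an at least 31-fold lower number from compound 1 to compound 3 (1.49 log units; beyond the scatter). Among the compounds shown, this is the first step that clearly lies beyond the scatter, and it brings a measured number well under the limit of the series. Compound 1 stands at a limit and not a number, so the step gives only a floor for the true size of the change: the limit of > 100000 nM in this assay, at which 1 of the 3 values shown sits.

The whole group changes at once, so the compounds shown do not separate the part played by the new five-membered non-aromatic ring from that of the rest of the entering group. On these data alone, whether an amine or a carboxylic acid on the same chain carbon would give a similar number also stays open.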